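The source may report more compounds than this note shows. Statements on the series, on what has been measured and on what is new or still open speak of the compounds shown alone.

Compound 1 `Fc1ccc(NCCNc2ccnc3cc(Cl)ccc23)cc1`: > 100 ug/mL
Compound 2 `N#Cc1ccc(NCCNc2ccnc3cc(Cl)ccc23)cc1`: 39.6 ug/mL
Compound 3 `Cc1ccc(NCCNc2ccnc3cc(Cl)ccc23)cc1`: > 100 ug/mL

All three share one core and differ only in the group on one aromatic carbon. In a toxicity assay on Huh-7 cells (Homo sapiens) for cytotoxicity, read by MTT assay, with a stated time of 72 h (a lower number here means that less compound is tolerated, a higher number that more compound is tolerated), compound 1 gives > 100 ug/mL, which is a limit of the assay rather than a number. Compound 1 thus stands at the limit of > 100 ug/mL in this assay, at which 2 of the 3 values shown sit.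

Compound 4 `Fc1ccc(NCCNc2ccnc3cc(Cl)ccc23)c(F)c1` is not yet measured; it differs from compound 1 by fluoro in place of hydrogen on an aromatic carbon. Among the measured compounds shown here, no measured step matches this change: an at least 2.5-fold lower number from compound 1 to compound 2 (0.40 log units; beyond the scatter) and an at least 2.5-fold higher number from compound 2 to compound 3 (0.40 log units; beyond the scatter) exchange the fluoro for other groups, while a step that the two limits leave unreadable from compound 1 to compound 3. Adding a second fluoro is therefore expected to give no step beyond the scatter in this assay. The estimate for compound 4 is 120 ug/mL, ranging from 60 ug/mL to 250 ug/mL, most likely reported again as a limit. This expected outcome corresponds to a step that the limit leaves unreadable from compound 1 to compound 4.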

Compound 4, half-maximal cytotoxic concentration: > 100 ug/mL
Compound 4 was reported as a limit; the forecaster's own chance of this, stated with the estimate: 70%; the middle value is on the limit's open side.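

Among the compounds shown here, compound 1 and compound 4 are both reported only as limits, so no step between them can be read: the limit of > 100 ug/mL in this assay, at which 3 of the 4 values shown sit. As far as these compounds go, whether the added fluoro changes the tolerated amount in this assay stays open, since neither compound has an exact value.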